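Cytotoxicity expected from a pentylamino amide

The source may report more compounds than this note shows. Statements on the series, on what has been measured and on what is new or still open speak of the compounds shown alone.

Of the compounds shown here, three sharing one core have been measured in an ADME assay on CEM-SS cells (Homo sapiens) for cytotoxicity, read by XTT assay, with a stated time of 6 days; on this read-out lower numbers stand for higher toxicity in this test and higher numbers for lower toxicity in this test. Compound 1 `CCCC(=O)OCSc1ccccc1C(=O)NCC(N)=O` returns only a limit, > 100 uM. Compound 2 `CCCC(=O)OCSc1ccccc1C(=O)NCCCCCNC(C)=O` gives 9.2 uM, and compound 3 `CCCC(=O)OCSc1ccccc1C(=O)NCC(=O)N(C)C` gives 38.3 uM. Compound 3 therefore holds the higher of the two actual numbers, and compound 2 is its nearest neighbour.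

Compound 4 `CCCCCNC(=O)CNC(=O)c1ccccc1SCOC(=O)CCC` departs from compound 3 in one place: pentylamino in place of dimethylamino on a carbonyl carbon. Pentylamino takes the place of dimethylamino on a carbonyl carbon. Within the data shown here, the closest precedent is a change on that same carbonyl carbon, an at least 2.6-fold lower number from compound 1 to compound 3 (0.41 log units; beyond the scatter), an at least modest fall when dimethylamino replaced amino. The other two steps concern the longer 4-acetamidobutyl group: an at least 10-fold lower number from compound 1 to compound 2 (1.03 log units; beyond the scatter) is large, and a 4.2-fold higher number from compound 2 to compound 3 (0.62 log units; beyond the scatter) is modest. Among these three compounds, the lowest number belongs to compound 2, which carries the longest chain, and no compound yet measured goes against that ordering. A modest move towards higher toxicity is thus expected, bringing compound 4 close to compound 2 without clearly passing it. The expected step is a 2.7-fold lower number from compound 3 to compound 4 (0.44 log units; beyond the scatter). Compound 4 is estimated at 14 uM, with an expected range of 5 uM to 35 uM.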

Compound 4, half-maximal toxic concentration: 24.8 uM
Compound 4: middle estimate off by 1.8-fold (0.25 log units), on the low side; low and high end bracket the measured number.
By their numbers in this assay, from the lowest: compound 2; then compounds 4 and 3 (each within the scatter of the next). At a limit, above all of these: compound 1.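

In this assay, pentylamino and dimethylamino on this carbonyl carbon cannot be told apart, with a 1.5-fold lower number from compound 3 to compound 4 (0.19 log units; within the scatter), so this larger group with its hydrogen-bond donor brings no change beyond the scatter at this position. Compound 4 also shows that a long chain does not by itself place a compound with compound 2: a 2.7-fold higher number from compound 2 to compound 4 (0.43 log units; beyond the scatter), and compound 4 therefore goes against the earlier ordering by chain length, even though compound 2 still gives the lowest number. Pentyl in place of hydrogen on an amide-type nitrogen gives an at least 4.0-fold lower number from compound 1 to compound 4 (0.60 log units; beyond the scatter), but compound 1 is a limit and not a number, so the true size of this step stays unknown: the limit of > 100 uM in this assay, at which 1 of the 4 values shown sits.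

What sets compound 2 apart remains open, since pentylcarbamoyl and 4-acetamidobutyl differ as whole groups and the compounds shown do not separate the effect of the acetamido end from that of the chain. Also open, as far as these compounds go, is how a hexylamino or piperidinyl group on this carbonyl carbon, or a carboxylic acid at the end of the pentyl chain, would read in this assay.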